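Changing the Aryl Group on a Shared Thiazole Core

The source may hold more compounds than are shown below. What is called first, only, known or untested is meant among the compounds shown, and "the series" means these compounds.

Compound 1 `COc1ccc2nc(N(Cc3cc(-c4ccc(SC(F)(F)F)cc4)no3)c3nc4ccc(F)cc4s3)sc2c1`: 11100 nM
Compound 2 `COc1ccc2nc(N(Cc3cc(-c4ccc(Br)cc4)no3)c3nc4ccc(F)cc4s3)sc2c1`: 7000 nM

Among the compounds with values here, in a functional assay on COLO 205 cells (Homo sapiens) for antiproliferative activity, read by MTT assay (on this read-out higher numbers stand for weaker inhibition and lower numbers for stronger inhibition), compound 2 holds the lowest of the two numbers measured so far, and the only other value lies within the scatter of it: a 1.6-fold lower number from compound 1 to compound 2 (0.20 log units; within the scatter). Compound 3 `COc1ccc2nc(N(Cc3cc(-c4ccccc4F)no3)c3nc4ccc(F)cc4s3)sc2c1` has not been measured; it differs by 2-fluorophenyl in place of 4-bromophenyl on an aromatic carbon. Within the data shown here, the single measured step also exchanged the group on this aryl ring and stayed within the scatter, so no movement beyond the scatter is expected from that change in this assay. The step expected from compound 2 to compound 3 is a 1.1-fold higher number from compound 2 to compound 3 (0.06 log units; within the scatter). Compound 3 is estimated at 8000 nM, within a range from 3000 nM to 25000 nM.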

Compound 3, half-maximal inhibitory concentration: 13400 nM
Compound 3: middle estimate off by 1.7-fold (0.22 log units), on the low side; the range from low to high includes it.
By their numbers in this assay, from the lowest: compounds 2, 1 and 3 (each within the scatter of the next).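

Compound 3 carries 2-fluorophenyl where compound 2 has 4-bromophenyl and compound 1 has 4-((trifluoromethyl)sulfanyl)phenyl, and in this assay this exchange gives a 1.9-fold higher number from compound 2 to compound 3 (0.28 log units; within the scatter) and a 1.2-fold higher number from compound 1 to compound 3 (0.08 log units; within the scatter). Three different aryl groups at this carbon, including one with its substituent at a different place on the phenyl ring, therefore cannot be told apart in this assay. Nothing available explains why these numbers stay so close. Still open, as far as these compounds go, is whether an aryl ring bearing an amine or a carboxylic acid would move the number beyond the scatter.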